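The compounds below may be only part of what the source reports. "The series", "measured", "known", "first", "only" and "open" are said of these compounds alone.

In an assay on isolated protein for inhibition of cathepsin D (Bos taurus) (a lower number here means a stronger inhibitor, a higher number a weaker inhibitor), compound 1 `CC(C)CCNC(=O)[C@H](C)NC(=O)C[C@H](C)[C@@H](CC(C)C)NC(=O)[C@@H](NC(=O)[C@@H](NC(=O)OC(C)(C)C)C(C)C)C(C)C` gives 31 nM; 47 nM (2 entries). Within the data shown here, compound 2 `CC(C)CCNC(=O)[C@H](C)NC(=O)C[C@H](O)[C@H](CC(C)C)NC(=O)[C@@H](NC(=O)OC(C)(C)C)C(C)C` stands far higher in this assay: compound 2 gives 2700 nM, the only number recorded for it, alongside one entry without a single value. Compound 3 `CC(C)CCNC(=O)[C@H](C)NC(=O)C[C@H](O)[C@H](CC(C)C)NC(=O)[C@@H](NC(=O)C(C)C)C(C)C` has not yet been measured. It differs from compound 2 in one place: isopropyl in place of tert-butoxy on a carbonyl carbon. Among the measured compounds shown here, no measured pair here shows such an exchange, so the expected step is estimated as a 1.3-fold higher number from compound 2 to compound 3 (0.11 log units; within the scatter), little or nothing beyond the usual scatter, if anything towards a weaker inhibitor. Compound 3 is accordingly expected to give about 3500 nM, within 1200 nM and 10000 nM.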

Compound 3, inhibition constant: 590 nM
Compound 3: the middle estimate sits 5.9-fold (0.77 log units) above what was measured; measured number outside the range, below it.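

In this assay, tert-butoxy on this carbonyl carbon proves unnecessary for inhibition: isopropyl in its place gives a 4.6-fold lower number from compound 2 to compound 3 (0.66 log units; beyond the scatter), towards a stronger inhibitor. The hydrogen-bond acceptor that leaves with tert-butoxy is therefore not required for this level of inhibition. The step is also larger than the spread between repeat entries for a single compound: the several entries of compound 1 in this assay, 31 nM; 47 nM (2 entries)

The compounds shown do not separate the loss of the oxygen from the change in the group's size. A tert-butyl group on the same carbonyl carbon would separate them, while a methyl group or a longer chain would show how much this position tolerates.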